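Swapping the Piperidine for a Cyclohexyl Thioether

This account rests on a few compounds, and the source may have more. Where it says the series, first, only, none or still open, it means among the compounds named here.

Measured so far:
Compound 1, `CC1CCN(c2nc(C(F)F)ccc2CNC(=O)C(C)c2ccc(NS(C)(=O)=O)c(F)c2)CC1`: 1 nM
Compound 2, `CC1CC(C)CN(c2nc(C(F)(F)Cl)ccc2CNC(=O)C(C)c2ccc(NS(C)(=O)=O)c(F)c2)C1`: 1 nM

Of the compounds shown here, two have been tested in an assay on CHO cells for antagonist activity at transient receptor potential cation channel subfamily V member 1 (Homo sapiens), read by FLIPR; on this read-out lower numbers stand for stronger inhibition and higher numbers for weaker inhibition. Compound 1 has the structure `CC1CCN(c2nc(C(F)F)ccc2CNC(=O)C(C)c2ccc(NS(C)(=O)=O)c(F)c2)CC1` and gives 1 nM. Compound 2, with the structure `CC1CC(C)CN(c2nc(C(F)(F)Cl)ccc2CNC(=O)C(C)c2ccc(NS(C)(=O)=O)c(F)c2)C1`, gives 1 nM. On these numbers compound 2 stands level with compound 1; the two values sit within the scatter of each other, so no order between them can be read from them.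

The next compound, compound 3, has the structure `CC(C(=O)NCc1ccc(C(F)(F)Cl)nc1SC1CCCCC1)c1ccc(NS(C)(=O)=O)c(F)c1`. It differs from compound 2 in a single place, where the change is cyclohexylsulfanyl in place of 3,5-dimethylpiperidin-1-yl on an aromatic carbon. Among the compounds with values here, no pair of measured compounds differs in that way, so the size of this step has no measured precedent. Because compound 2 gives 1 nM, a value this strong leaves little room for further gain, and the replacement of the nitrogen-containing ring by a carbon-only ring joined through sulfur is a sizeable change. A moderate weakening is expected, that is, the step of a 5.0-fold higher number from compound 2 to compound 3 (0.70 log units; beyond the scatter). Compound 3 is therefore estimated at 5 nM, with a range from 1 nM to 30 nM.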

Compound 3, inhibition constant: 3 nM
The estimate for compound 3 lay 1.7-fold (0.22 log units) above the measured number; low and high end bracket the measured number.
By their numbers in this assay, from the lowest: compounds 1 and 2 (each within the scatter of the next); then compound 3.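

In this assay, the place next to the ring nitrogen tolerates a large change of group: putting cyclohexylsulfanyl in place of 3,5-dimethylpiperidin-1-yl gives a 3.0-fold higher number from compound 2 to compound 3 (0.48 log units; beyond the scatter) and counts as a modest loss. The piperidine nitrogen is therefore not essential for strong inhibition in this series, since compound 3, with a carbon-only six-membered ring joined through sulfur, still gives 3 nM on this read-out, yet the swap does carry a real cost. This single step changes the joining atom, removes the ring nitrogen and drops both methyl groups at once, and the data shown offer no explanation for its size.

Which of these parts accounts for the step remains open, and a cyclohexyloxy or cyclohexylamino group at the same place would separate the joining atom from the ring. From the compounds shown here alone, it is also open whether the step would keep its size with difluoromethyl in place of chloro(difluoro)methyl, the group carried by compound 1.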